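Acylsulfonamide replacing the pyrrolidinyl amide in the series

The compounds below may be only part of what the source reports. "The series", "measured", "known", "first", "only" and "open" are said of these compounds alone.

Going by the values given here, compound 2 `Cc1cc(C)cc(S(=O)(=O)c2c(C(=O)N[C@H]3CCN(CC(N)=O)C3)[nH]c3ccc(Cl)cc23)c1` gives 28100 nM in an ADME assay on MT4 cells (Homo sapiens) for cytotoxicity, read by MTT assay, with a stated time of 5 days (on this read-out higher numbers stand for lower toxicity in this test and lower numbers for higher toxicity in this test), the lower of the two numbers so far. Among the compounds with values here, compound 1 `Cc1cc(C)cc(S(=O)(=O)c2c(C(=O)N[C@H]3CCN(Cc4ccccc4F)C3)[nH]c3ccc(Cl)cc23)c1` gives 215000 nM in this assay; the one measured step, a 7.7-fold lower number from compound 1 to compound 2 (0.88 log units; beyond the scatter), concerns a group on the ring amine, not the amide nitrogen.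

Compound 3 `Cc1cc(C)cc(S(=O)(=O)c2c(C(=O)NS(=O)(=O)C(F)(F)F)[nH]c3ccc(Cl)cc23)c1` is the next compound: (trifluoromethyl)sulfonyl in place of 1-(carbamoylmethyl)pyrrolidin-3-yl on an amide-type nitrogen. Within the data shown here, no measured step touches this position, so the only guide is the spread of the two numbers seen. The direction of a 2.1-fold higher number from compound 2 to compound 3 (0.33 log units; beyond the scatter) is therefore expected to be uncertain, with a move toward the middle of the observed range as the central guess. For compound 3 in this assay the estimate is 60000 nM, with a range from 15000 nM to 250000 nM that covers both measured compounds.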

Compound 3, half-maximal cytotoxic concentration: 141000 nM
Beside the measured number, compound 3's estimate is 2.4-fold (0.37 log units) below it, within the range that was stated.
By their numbers in this assay, from the lowest: compound 2; then compounds 3 and 1 (each within the scatter of the next).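

In this assay the amide-type nitrogen is a second place where the number moves, with a 5.0-fold higher number from compound 2 to compound 3 (0.70 log units; beyond the scatter) on going from 1-(carbamoylmethyl)pyrrolidin-3-yl to (trifluoromethyl)sulfonyl. This change removes the five-membered ring and the defined stereocentre, yet compound 3 lies within the scatter of compound 1, so the ring is not required for a number in the upper part of those seen so far. No available evidence bears on the reason for this shift.

As far as these compounds go, it remains open whether the number follows the sulfonyl group itself or only the loss of the pyrrolidine ring. A methylsulfonyl or phenylsulfonyl group on the same nitrogen, or a carboxylic acid in place of the whole acylsulfonamide, would help to separate these two readings.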